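A few compounds are considered here, and "the series" means these few. Any claim that something is new, unique, unknown or untested is made for them only; others in the source may bear on it.

Compound 1 `CCCCCCCCCCCCCCCCCCNC(=O)[C@@H](NC(=O)c1nccc2ccccc12)[C@@H](C)O`: 30800 nM
Compound 2 `CCCCCCCCCCCCCCCCCCNC(=O)[C@@H](NC(=O)/C=C/c1ccccc1)[C@@H](C)O`: 39200 nM

In a functional assay on MCF7 cells (Homo sapiens) for cytotoxicity, read by MTT assay, with a stated time of 48 h (on this read-out lower numbers stand for stronger inhibition and higher numbers for weaker inhibition), the two measured numbers sit close together; the step of a 1.3-fold higher number from compound 1 to compound 2 (0.10 log units; within the scatter) is within the scatter, so compound 2 cannot be set apart from compound 1 on these numbers. Compound 3 `CCCCCCCCCCCCCCCCCCNC(=O)[C@@H](NS(=O)(=O)c1ccc(C)cc1)[C@@H](C)O` differs from compound 2 in one place: (4-methylphenyl)sulfonyl in place of (2-phenylethenyl)carbonyl on an amine nitrogen. Going by the values given here, the single measured step replaced one carbonyl substituent with another and leaves the carbonyl itself untouched, so no measured step bears directly on exchanging the carbonyl for a sulfonyl. With nothing in the data pointing either way, compound 3 is expected to show no step beyond the scatter, which means an expected 1.0-fold higher number from compound 2 to compound 3 (0.01 log units; within the scatter). The estimate for compound 3 is therefore 40000 nM, with a wide range from 12000 nM to 130000 nM to reflect the lack of a matching precedent.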

Compound 3, half-maximal inhibitory concentration: 60100 nM
Compound 3: middle estimate off by 1.5-fold (0.18 log units), on the low side, within the range that was stated.
By their numbers in this assay, from the lowest: compounds 1, 2 and 3 (each within the scatter of the next).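

Measured in this assay the exchange of a carbonyl for a sulfonyl on the amine nitrogen gives a step from the cinnamoyl-type compound (a 1.5-fold higher number from compound 2 to compound 3 (0.19 log units; within the scatter)) and one from the isoquinoline compound (a 2.0-fold higher number from compound 1 to compound 3 (0.29 log units; within the scatter)). Both steps lie within the scatter, so (4-methylphenyl)sulfonyl cannot be set apart from (2-phenylethenyl)carbonyl or (isoquinolin-1-yl)carbonyl at this position. No measured evidence accounts for these numbers. Open, going by these compounds, is whether a methylsulfonyl or a plain acetyl on this nitrogen would step beyond the scatter. Also open, on these data alone, is what a shorter chain in place of the long saturated chain would do.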